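Halogen exchange on the sulfonyl-linked aryl ring

This account rests on a few compounds, and the source may have more. Where it says the series, first, only, none or still open, it means among the compounds named here.

Three measured members share one core and differ only in the group on an aromatic carbon of that core. Compound 1 `COc1ccc2ncc(S(=O)(=O)c3ccc(Cl)c(Cl)c3)c(N3CCC(C)CC3)c2c1` gives 87% in an assay on isolated protein for displacement of a labelled ligand from metabotropic glutamate receptor 5 (Homo sapiens), with a stated time of 60 min, tested at 1 uM; a lower number here means less inhibition, a higher number more inhibition at the concentration tested (going by the name of the read-out). Compound 2 `Cc1ccc2ncc(S(=O)(=O)c3ccc(Cl)c(Cl)c3)c(N3CCC(C)CC3)c2c1` gives 82% in this assay. Compound 3 `CC1CCN(c2c(S(=O)(=O)c3ccc(Cl)c(Cl)c3)cnc3ccc(F)cc23)CC1` gives 91% in this assay. Compound 2 shows the smallest of the three numbers as they stand, but its gaps to the others, a number 5 percentage points lower from compound 1 to compound 2 (within the scatter) and a number 9 percentage points higher from compound 2 to compound 3 (within the scatter), both lie within the scatter, as does a number 4 percentage points higher from compound 1 to compound 3 (within the scatter); the three compounds are not separated by these data.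

Compound 4 `Cc1ccc2ncc(S(=O)(=O)c3ccc(F)c(Cl)c3)c(N3CCC(C)CC3)c2c1` is compound 2 with fluoro in place of chloro on an aromatic carbon, the dichlorophenyl becoming a 3-chloro-4-fluorophenyl. Among the measured compounds shown here, no measured step touches this ring: all three recorded steps exchange groups on the core, and all three fall within the scatter. For the measured compounds named here, there is therefore no direct guide, and nothing among the measured compounds suggests a move beyond the scatter. Compound 4 is expected to sit close to compound 2, with an estimated step of a number 2 percentage points lower from compound 2 to compound 4 (within the scatter) in this assay. The estimate for compound 4 in this assay is 80%, within a range from 66% to 92%.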

Compound 4, a percentage reported as inhibition, at one concentration (the size of the read-out at that concentration, not a potency): 93%
For compound 4 the middle estimate is 13 percentage points below the measured one, outside the stated range (above it).
By their numbers in this assay, from the lowest: compounds 2, 1, 3 and 4 (each within the scatter of the next, the first and the last beyond it).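

In this assay, the change from 3,4-dichlorophenyl to 3-chloro-4-fluorophenyl gives a number 11 percentage points higher from compound 2 to compound 4 (beyond the scatter), a modest step but the only one in the series printed as beyond the scatter. The steps among the earlier compounds all exchanged groups on the shared core and all stayed within the scatter, so they gave no sign that the read-out could separate any pair of these compounds; this aryl carbon, ortho to a chloro group and para to a large group, is the one place shown where an exchange does so. No measurement on these compounds bears on why the fluoro member reads differently from the chloro member.

As far as these compounds go, this step is read on the methyl member of the core alone, so it remains open whether fluoro in place of chloro at this carbon has the same effect on the methoxy and fluoro members. Also open, from the compounds shown here alone, is how the same carbon responds to a group other than these halogens, such as a nitrile, a trifluoromethyl or an amine, and how the read-out at one concentration relates to potency across the series.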